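A few compounds are considered here, and "the series" means these few. Any claim that something is new, unique, unknown or untested is made for them only; others in the source may bear on it.

Measured so far in an assay on brain (strain Sprague-Dawley) for inhibition of Amine oxidase [flavin-containing] B (Rattus norvegicus), read by spectrophotometry; a higher number here means a weaker inhibitor, a lower number a stronger inhibitor:
- compound 1, `CCNC(=O)Nc1cc(=O)oc2cc(OCc3cccc(Cl)c3)ccc12`, 31600 nM
- compound 2, `O=C(O)COc1cc(=O)oc2cc(OCc3cccc(Cl)c3)ccc12`, 31600 nM
- compound 3, `N#CCCc1cc(=O)oc2cc(OCc3cccc(Cl)c3)ccc12`, 28.8 nM

Compound 1 stands level with compound 2 at the digits shown, the two together giving the highest numbers of the three, while compound 3 lies far below them, as the step of a 1100-fold lower number from compound 1 to compound 3 (3.04 log units; beyond the scatter) shows. The step of no change at the digits printed from compound 1 to compound 2 (within the scatter) shows that exchanging the (ethylcarbamoyl)amino group for carboxymethoxy leaves the number where it was.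

Compound 4, `O=C(CCl)Nc1cc(=O)oc2cc(OCc3cccc(Cl)c3)ccc12`, is not yet measured. It differs from compound 1 in one place: chloromethyl in place of ethylamino on a carbonyl carbon. The ((chloromethyl)carbonyl)amino group of compound 4 keeps the amide-type nitrogen of compound 1 and changes only what sits on the carbonyl carbon.

Of the measured steps, no change at the digits printed from compound 1 to compound 2 (within the scatter) bears most on this change, since it too swaps one group on the aromatic carbon while keeping compound 1 otherwise unchanged, and it moved nothing. The large step of a 1100-fold lower number from compound 1 to compound 3 (3.04 log units; beyond the scatter) came from a 2-cyanoethyl group, which compound 4 does not carry. A step of about a 2.1-fold lower number from compound 1 to compound 4 (0.32 log units; beyond the scatter) is therefore expected, at most a modest lowering. For compound 4 the estimate is 15000 nM, expected to fall between 3500 nM and 50000 nM.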

Compound 4, half-maximal inhibitory concentration: 398 nM
Beside the measured number, compound 4's estimate is 38-fold (1.58 log units) above it; the whole stated range lies above it.
By their numbers in this assay, from the lowest: compound 3; then compound 4; then compounds 1 and 2 (each within the scatter of the next).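

In this assay, the (ethylcarbamoyl)amino group can be altered on its carbonyl carbon alone, with the amide-type nitrogen kept, and still give a large shift: chloromethyl in place of ethylamino gives a 79-fold lower number from compound 1 to compound 4 (1.90 log units; beyond the scatter), so keeping that nitrogen on the aromatic carbon does not by itself hold the number high. Until now, only the 2-cyanoethyl group had moved the number away from the high level, whereas the new group also stands well clear of carboxymethoxy, with a 79-fold lower number from compound 2 to compound 4 (1.90 log units; beyond the scatter), yet it does not reach the level of 2-cyanoethyl, with a 14-fold higher number from compound 3 to compound 4 (1.14 log units; beyond the scatter), so this position now shows three distinct levels rather than two. No measurement here accounts for the effect of the change on the carbonyl carbon.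

The compounds shown cannot separate the arrival of the chlorine from the departure of the ethylamino group, and a plain methyl or ethyl on the same carbonyl carbon would bear on that. Also open, as far as these compounds go, is whether a bromomethyl group there, or a longer chloroalkyl chain, would give a number closer to that of 2-cyanoethyl.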